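The source may report more compounds than this note shows. Statements on the series, on what has been measured and on what is new or still open speak of the compounds shown alone.

Measured so far in a functional assay on A549 cells (Homo sapiens) for cytotoxicity, read by MTT assay, with a stated time of 48 h; a lower number here means a stronger inhibitor, a higher number a weaker inhibitor:
compound 1, `COc1ccc(N/C=C\C(=O)c2nc(-c3ccc(F)cc3)n3ccccc23)cc1OC`, gives > 30000 nM, a limit of the assay
compound 2, `COc1ccc(-c2nc(C(=O)/C=C\Nc3ccc(F)cc3)c3ccccn23)cc1`, gives > 30000 nM, a limit of the assay
compound 3, `COc1ccc(-c2nc(C(=O)/C=C\Nc3ccc4[nH]ccc4c3)c3ccccn23)cc1`, gives 4800 nM

Compound 1 stands at the edge of what this assay can report: its value is a limit, not a number, and it shares that position with compound 2, as the limit of > 30000 nM in this assay, at which 2 of the 3 values shown sit, records. Only compound 3 gives a number at all.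

Compound 4, `O=C(/C=C\Nc1ccc(Cl)cc1)c1nc(-c2ccc(F)cc2)n2ccccc12`, differs from compound 1 in one place: 4-chlorophenyl in place of 3,4-dimethoxyphenyl on an amine nitrogen.

Going by the values given here, the one measured step on this amine nitrogen runs the other way. In an at least 6.2-fold lower number from compound 2 to compound 3 (0.79 log units; beyond the scatter) a 1H-indol-5-yl replaced a 4-fluorophenyl and the number fell clearly beyond the scatter, so in this series the halogen-bearing phenyl sits at the limit and the indolyl moves off it. Compound 4 carries a 4-chlorophenyl, a close relative of the 4-fluorophenyl of compound 2, and leaves behind the 3,4-dimethoxyphenyl of compound 1, which also sat at the limit. Among the compounds with values here, no measured pair compares two such halophenyls directly.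

Compound 4 is therefore expected to remain at the limit, with an estimated value of 40000 nM (range 9000 nM to 150000 nM). The expected step is a step that the limit leaves unreadable from compound 1 to compound 4, that is, no change beyond the scatter.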

Compound 4, half-maximal inhibitory concentration: 5090 nM
For compound 4 the middle estimate is 7.9-fold (0.90 log units) above the measured one; the measured number lies below the stated range.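

In this assay, the change on the amine nitrogen gives an at least 5.8-fold lower number from compound 1 to compound 4 (0.77 log units; beyond the scatter), which means that a simple 4-chlorophenyl at this position can bring a compound off the limit, with the rest of the structure left untouched. Going by these compounds alone, until now, the only step off the limit at this nitrogen was an at least 6.2-fold lower number from compound 2 to compound 3 (0.79 log units; beyond the scatter), which involved a 1H-indol-5-yl, and the new step shows that a two-ring group of that kind is not the only route to a readable number. The full size of the new step cannot be read because compound 1 gives a limit of the assay rather than a number: the limit of > 30000 nM in this assay, at which 2 of the 4 values shown sit.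

The single change removes the two methoxy groups and brings in a chlorine at the same time, and the compounds shown cannot separate the loss of one from the gain of the other. Also open, from the compounds shown here alone, is how an unsubstituted phenyl, a 4-bromophenyl or a 4-aminophenyl on this nitrogen would read against compound 4 on the same core.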